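The compounds below may be only part of what the source reports. "The series", "measured", "known", "first", "only" and "open" are said of these compounds alone.

Of the compounds shown here, two sharing a core have so far been measured in an in vitro assay on BTI-TN-5B1-4 cells for inhibition of Amine oxidase [flavin-containing] A (Homo sapiens), read by fluorescence; a lower number here means a stronger inhibitor, a higher number a weaker inhibitor. Compound 1, `O=C(Nc1c(F)c(F)nc(F)c1F)c1cc2ccccc2oc1=O`, gives 11400 nM in this assay. Compound 2, `O=C(Nc1ccccc1Cc1ccccc1)c1cc2ccc(OCc3ccccc3)cc2oc1=O`, gives 51900 nM in this assay. Compound 2 thus carries the highest of the two numbers; its nearest neighbour is compound 1, whose lower number lies beyond the usual scatter, so compound 2 is the weaker inhibitor of the pair.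

Compound 3, `O=C(Nc1ccccc1Cc1ccccc1)c1cc2ccc(OCc3ccc(F)cc3)cc2oc1=O`, has not yet been measured. It differs from compound 2 by fluoro in place of hydrogen on an aromatic carbon, a fluoro in place of hydrogen on an aromatic carbon, para to a large group, so that the benzyloxy of compound 2 becomes a (4-fluorobenzyl)oxy. Within the data shown here, no pair of measured compounds differs in this way, so there is no step on hand to guide the expectation. Under these conditions the expected step of a 1.2-fold lower number from compound 2 to compound 3 (0.06 log units; within the scatter) is small, not beyond the scatter in either direction. Compound 3 is therefore estimated at 45000 nM in this assay, with a range from 15000 nM to 130000 nM.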

Compound 3, half-maximal inhibitory concentration: 55800 nM
The estimate for compound 3 lay 1.2-fold (0.09 log units) below the measured number; the range from low to high includes it.
By their numbers in this assay, from the lowest: compound 1; then compounds 2 and 3 (each within the scatter of the next).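

In this assay, fluoro in place of hydrogen on an aromatic carbon, para to a large group, turns the benzyloxy of compound 2 into the (4-fluorobenzyl)oxy of compound 3 and gives a 1.1-fold higher number from compound 2 to compound 3 (0.03 log units; within the scatter). Among these compounds, this is the first step that can be read between two compounds differing in one place, and it shows that this single fluorine leaves the two compounds indistinguishable in this assay, so the change has no effect that can be told from the scatter of repeated measurements. Nothing at hand bears on why the number stays as it does.

On these data alone, this one step covers only fluoro at this one place, so it remains open whether a chloro, a methoxy, a trifluoromethyl or an amine there would also leave the number within the scatter, and whether fluoro would behave the same way elsewhere on this ring. The compounds shown also include no pair that isolates the benzyloxy itself, so what that group contributes, compared with a plain hydrogen or a methoxy at its place on the shared core, cannot be read from them.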